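Urea-to-amide switch on the carbonyl of compound 3

The source may report more compounds than this note shows. Statements on the series, on what has been measured and on what is new or still open speak of the compounds shown alone.

All three measured compounds share one core and differ only in the group on the carbonyl carbon of the anilide. Compound 1 `COc1cc(-c2nn(-c3cccc(NC(=O)Nc4cccc(C(F)(F)F)c4)c3)cc2-c2ccncc2)ccc1Cl` gives 1870 nM in a functional assay on M14 cells (Homo sapiens) for inhibition, read by sulforhodamine B assay, with a stated time of 48 h; on this read-out higher numbers stand for weaker inhibition of growth and lower numbers for stronger inhibition of growth. Compound 3 `COc1cc(-c2nn(-c3cccc(NC(=O)Nc4ccc(Cl)c(C(F)(F)F)c4)c3)cc2-c2ccncc2)ccc1Cl` gives 3710 nM in this assay, and the step of a 2.0-fold higher number from compound 1 to compound 3 (0.30 log units; within the scatter) leaves the two compounds indistinguishable, so compound 3 simply holds the higher of the two plain numbers. Compound 2 `COc1cc(-c2nn(-c3cccc(NC(=O)c4ccc(Cl)c(C(F)(F)F)c4)c3)cc2-c2ccncc2)ccc1Cl` reaches only a limit of the assay in this assay, > 32500 nM. Both steps that replace the urea nitrogen link by a direct aryl amide were large and both ran against the amide: an at least 17-fold higher number from compound 1 to compound 2 (1.24 log units; beyond the scatter) and an at least 8.7-fold lower number from compound 2 to compound 3 (0.94 log units; beyond the scatter), each resting on the limit (the limit of > 32500 nM in this assay, at which 1 of the 3 values shown sits). Compound 4 `COc1cc(-c2nn(-c3cccc(NC(=O)c4ccccc4)c3)cc2-c2ccncc2)ccc1Cl` is not yet measured; its change from compound 3 is phenyl in place of (4-chloro-3-(trifluoromethyl)phenyl)amino on a carbonyl carbon. Among the measured compounds shown here, the change also removes the chloro and trifluoromethyl groups from the outer ring; the only guide to the ring substituents is a 2.0-fold higher number from compound 1 to compound 3 (0.30 log units; within the scatter), which stayed within the scatter, so the urea-to-amide move is taken as the governing step. For compound 4 a large rise in this assay is therefore expected, an 8.1-fold higher number from compound 3 to compound 4 (0.91 log units; beyond the scatter). The estimate for compound 4 is 30000 nM, in the range 8000 nM to 100000 nM, with a limit rather than a number the more likely outcome.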

Compound 4, concentration for total growth inhibition: 12900 nM
The estimate for compound 4 lay 2.3-fold (0.37 log units) above the measured number; measured number inside the range.
By their numbers in this assay, from the lowest: compounds 1 and 3 (each within the scatter of the next); then compound 4. At a limit, above all of these: compound 2.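

Compound 4 shows that the amide link on this carbonyl carbon does not by itself take the series to the assay limit, since the plain phenyl amide keeps a real number in this assay. Against the ureas the cost is smaller than compound 2 suggested, at a 3.5-fold higher number from compound 3 to compound 4 (0.54 log units; beyond the scatter) and a 6.9-fold higher number from compound 1 to compound 4 (0.84 log units; beyond the scatter), so the urea compounds remain ahead of compound 4 beyond the scatter. Among the amides the outer ring now makes a readable difference, at an at least 2.5-fold lower number from compound 2 to compound 4 (0.40 log units; beyond the scatter), whereas the chloro group on the urea series gave only a 2.0-fold higher number from compound 1 to compound 3 (0.30 log units; within the scatter); this amide comparison rests on a limit, not on a number: the limit of > 32500 nM in this assay, at which 1 of the 4 values shown sits.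

Which of the chloro and trifluoromethyl groups accounts for the gap between the two amides stays open, and so does the size of the urea-to-amide step with a plain phenyl on both sides, for which a phenyl urea would be the direct partner of compound 4. Also open, on these data alone, is how the amide tolerates other groups on the outer phenyl ring, such as a carboxylic acid or a dimethylamino group.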